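From iodo to methoxy in a growth inhibition series

The source may report more compounds than this note shows. Statements on the series, on what has been measured and on what is new or still open speak of the compounds shown alone.

compound 1 `NC(=O)c1cc(Cl)ccc1NC(=O)COc1ccccc1` with 854 nM
compound 2 `NC(=O)c1cc(I)ccc1NC(=O)COc1ccccc1` with 161 nM

For the measured compounds named here, in a functional assay on K562 cells (Homo sapiens) for inhibition (on this read-out higher numbers stand for weaker inhibition of growth and lower numbers for stronger inhibition of growth), compound 2 at 161 nM holds the lower of the two numbers so far. Compound 3 `COc1ccc(NC(=O)COc2ccccc2)c(C(N)=O)c1` differs from it by one change, methoxy in place of iodo on an aromatic carbon which reads methoxy in place of iodo on an aromatic carbon. Going by the values given here, the only measured step at this place is a 5.3-fold lower number from compound 1 to compound 2 (0.72 log units; beyond the scatter) for iodo in place of chloro, and on that size a similar step toward a higher number is expected, as no methoxy compound has been measured. The expected step is a 5.0-fold higher number from compound 2 to compound 3 (0.70 log units; beyond the scatter) by this estimate. Compound 3 is estimated at 800 nM with an expected range from 250 nM to 2500 nM in this read-out.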

Compound 3, concentration for 50% growth inhibition: 245 nM
Compound 3: the middle estimate sits 3.3-fold (0.51 log units) above what was measured; the whole stated range lies above it.
By their numbers in this assay, from the lowest: compounds 2 and 3 (each within the scatter of the next); then compound 1.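

In this assay, the exchange of iodo for methoxy gives a 1.5-fold higher number from compound 2 to compound 3 (0.18 log units; within the scatter), so two groups that share no atoms sit within the scatter of each other at this place on the ring, para to a large group. The change from chloro to methoxy gives a 3.5-fold lower number from compound 1 to compound 3 (0.54 log units; beyond the scatter), which shows that the gap from chloro is not peculiar to iodo. Nothing available here accounts for this result. The compounds shown leave open whether an amine, a carboxylic acid or a longer chain such as ethoxy at this place would read like compound 2 and compound 3 or like compound 1.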